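The source may report more compounds than this note shows. Statements on the series, on what has been measured and on what is new or still open speak of the compounds shown alone.

Working notes on the series. Compound 1 `CCCCCCCCCCC(C)(C)C(=O)Nc1c(C)c(N)c(C)c2c1OC(C)(C)C2` gives 59 nM in an assay for inhibition of acyl-CoA:cholesterol acyltransferase (Oryctolagus cuniculus), using microsomes; on this read-out higher numbers stand for weaker inhibition and lower numbers for stronger inhibition. Compound 2 `CCCCCCCCCCC1(C(=O)Nc2c(C)ccc3c2OC(C)(C)C3)CCCC1` gives 240 nM in this assay. Compound 3 `Cc1cc(C)c(NC(=O)C(C)(C)CCCCCCN2CCCCC2)c2c1CC(C)(C)O2` reaches only the limit of this assay, > 500 nM; this is a limit, not a number, so compound 3 stands among the weakest shown, and its place is marked by the limit of > 500 nM in this assay, at which 1 of the 3 values shown sits. Compound 4 `Cc1cc(C)c(NC(=O)C(C)(C)CCCc2ccc(CC(C)C)cc2)c2c1CC(C)(C)O2` is not yet measured; the change from compound 3 is 4-isobutylphenyl in place of 3-(piperidin-1-yl)propyl on a saturated chain carbon, four bonds along the chain from a carbonyl carbon. Compound 4 is expected to inhibit more strongly than compound 3, since compound 1 gives 59 nM with a carbon chain that carries no nitrogen on the amide side. The step of an at least 3.3-fold lower number from compound 3 to compound 4 (0.52 log units; beyond the scatter) is expected to go toward stronger inhibition, beyond the scatter. Compound 4 is estimated at 150 nM, within 40 nM to 600 nM.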

Compound 4, half-maximal inhibitory concentration: 40 nM
For compound 4 the middle estimate is 3.8-fold (0.57 log units) above the measured one; measured number inside the range.
By their numbers in this assay, from the lowest: compounds 4 and 1 (each within the scatter of the next); then compound 2. At a limit, above all of these: compound 3.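

This position gives the series its first step in one place: in this assay, 4-isobutylphenyl in place of 3-(piperidin-1-yl)propyl gives an at least 12-fold lower number from compound 3 to compound 4 (1.09 log units; beyond the scatter). Compound 3 stands at a limit of the assay, not a number: the limit of > 500 nM in this assay, at which 1 of the 4 values shown sits.

The chain position therefore accepts an all-carbon aromatic group with strong inhibition, and the size of the step is known only as a bound. The compounds shown leave open whether the step follows the loss of the piperidine nitrogen or the arrival of the aromatic ring. An unsubstituted phenyl or a 4-isobutylcyclohexyl group at this place would separate the two.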